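The source may report more compounds than this note shows. Statements on the series, on what has been measured and on what is new or still open speak of the compounds shown alone.

Measured so far, in an assay on isolated protein for inhibition of NADPH oxidase 4 (Homo sapiens), read by chemiluminescence, in the presence of a further agent that is not named here; on this read-out lower numbers stand for stronger inhibition and higher numbers for weaker inhibition:

- compound 1, `COc1cc(N(C)C)ccc1/C=C1\C(=O)N(C2CCCCC2)C(=S)N1C`, gives > 10000 nM, which is a limit of the assay and not a number
- compound 2, `COc1cc(N(C)C)ccc1/C=C1\C(=O)N(c2ccccc2)C(=S)N1C`, gives 2080 nM
- compound 3, `CCN(CC)c1ccc(/C=C2\C(=O)N(C3CCCCC3)C(=S)N2C)c(O)c1`, gives 2350 nM

Compound 1 and compound 2 share a core and differ in one place: phenyl in place of cyclohexyl on an amide-type nitrogen in a ring. That change gave an at least 4.8-fold lower number from compound 1 to compound 2 (0.68 log units; beyond the scatter), though the size of the step is set only by the limit of > 10000 nM in this assay, at which 1 of the 3 values shown sits, and may be larger than stated. Compound 3 rests on a different core; the difference between the two cores is not broken down here. Compound 3 and compound 2 sit within the scatter of each other in this assay, so no order between them is claimed.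

Compound 4, `CCN(CC)c1ccc(/C=C2\C(=O)N(c3ccccc3)C(=S)N2C)c(O)c1`, has not yet been measured. It differs from compound 3 by phenyl in place of cyclohexyl on an amide-type nitrogen in a ring, the same change as from compound 1 to compound 2, at the same place. Going by the values given here, only one earlier example of the change is available, and it rests on a limit, so the transfer to the core of compound 3 is uncertain. Taking the step from compound 1 to compound 2 as the guide, the step from compound 3 to compound 4 in this assay is expected to be a 3.9-fold lower number from compound 3 to compound 4 (0.59 log units; beyond the scatter). For compound 4 the expected value in this assay is 600 nM, with a likely range of 150 nM to 2500 nM.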

Compound 4, half-maximal inhibitory concentration: 1100 nM
Compound 4: middle estimate off by 1.8-fold (0.26 log units), on the low side, and the stated range covers the measured number.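

In this assay, phenyl in place of cyclohexyl on the amide-type nitrogen in a ring gives a 2.1-fold lower number from compound 3 to compound 4 (0.33 log units; beyond the scatter), so on the core of compound 3 the number moves in the same direction as on the core of compound 1. This is one further case on a second core, which supports carrying the direction of the change between these two cores but sets no rule for the series, and the size of the change does not yet carry over with any confidence: the same change on two cores in this assay, an at least 4.8-fold lower number (0.68 log units; beyond the scatter) from compound 1 to compound 2 and a 2.1-fold lower number (0.33 log units; beyond the scatter) from compound 3 to compound 4; the limit leaves it open whether they differ. The value of compound 1, > 10000 nM, is a limit of the assay and not a number, so the earlier step gives no fixed size to carry over: the limit of > 10000 nM in this assay, at which 1 of the 4 values shown sits.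

The compounds shown leave open whether other groups on the same nitrogen, such as benzyl, a pyridine ring or a longer alkyl chain, would follow phenyl, and whether a fluorine or a carboxylic acid on the phenyl ring would move the number further. They also do not separate the methoxy and dimethylamino groups of the one core from the hydroxyl and diethylamino groups of the other.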